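This account rests on a few compounds, and the source may have more. Where it says the series, first, only, none or still open, it means among the compounds named here.

Compound 3 `O=S(=O)(c1cccc(F)c1)c1cnc2c(F)cccc2c1-c1cccc(Cl)c1` gives the lowest of the three numbers in an ADME assay on microsomes from liver (Homo sapiens) for metabolic stability, tested at 2.5 uM (on this read-out higher numbers stand for fast clearance and lower numbers for slow clearance), at 0.56 mL/min. Within the data shown here, its nearest neighbour is compound 2 `O=S(=O)(c1cc(F)cc(F)c1)c1cnc2c(F)cccc2c1-c1cccc(Cl)c1`, which gives 0.64 mL/min; the step of a 1.1-fold lower number from compound 2 to compound 3 (0.06 log units; within the scatter) is the only single-point change measured here and lies within the scatter. Differing from compound 3 in two places, compound 1 `O=S(=O)(c1ccc(F)c(Cl)c1)c1cnc2c(F)cccc2c1-c1ccccc1F` gives 1.39 mL/min, a number beyond the scatter above compound 3.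

Compound 4 `O=S(=O)(c1cccc(F)c1)c1cnc2c(F)cccc2c1-c1ccccc1F` is not yet measured. It differs from compound 3 as follows: 2-fluorophenyl in place of 3-chlorophenyl on an aromatic carbon. Among the measured compounds shown here, no measured step covers this change. For the measured compounds named here, the one step available, from compound 2 to compound 3, concerns a different part of the molecule and was within the scatter, so it says little about compound 4. Going by the values given here, compound 1, the only measured compound carrying the 2-fluorophenyl, shows a higher number than compound 3, but it also differs elsewhere, so only the two values themselves can be noted. The step to compound 4 is therefore expected to be small, a 1.4-fold higher number from compound 3 to compound 4 (0.15 log units; within the scatter), possibly upward but not with confidence. Compound 4 is estimated at 0.8 mL/min, within a range from 0.45 mL/min to 1.5 mL/min.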

Compound 4, intrinsic clearance in a liver preparation (reported as CLH), per the amount of preparation that the assay uses: 0.21 mL/min
Estimate against measurement, compound 4: 3.8-fold (0.58 log units) above; measured number outside the range, below it.
By their numbers in this assay, from the lowest: compound 4; then compounds 3 and 2 (each within the scatter of the next); then compound 1.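

In this assay, among these compounds, 2-fluorophenyl in place of 3-chlorophenyl on the aromatic carbon gives a 2.7-fold lower number from compound 3 to compound 4 (0.43 log units; beyond the scatter), the first measured change at this position and one that moves the number beyond the scatter. With the 2-fluorophenyl held constant, 3-fluorophenyl in place of 3-chloro-4-fluorophenyl on the sulfonyl sulfur gives a 6.6-fold lower number from compound 1 to compound 4 (0.82 log units; beyond the scatter), so this side of the molecule can also shift the read-out, although the earlier change there, a 1.1-fold lower number from compound 2 to compound 3 (0.06 log units; within the scatter), did not. No measured evidence is available here to explain either step.

The compounds shown leave open how a plain phenyl, a 2-chlorophenyl or a 3-fluorophenyl would read at this aromatic carbon, so the identity of the halogen and its place on the ring cannot be separated. Also open, as far as these compounds go, is how a ring carrying an amine or a carboxylic acid would read there.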